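Removing the chloro from compound 2: an expected small shift

The source may hold more compounds than are shown below. What is called first, only, known or untested is meant among the compounds shown, and "the series" means these compounds.

Measured so far:
compound 1 `O=C(Nc1ccccc1)Nc1nc(NC2CC2)cc(Sc2c[nH]c3ccccc23)n1`, in a functional assay on MDA-MB-231 cells (Homo sapiens) for inhibition, with a stated time of 72 h (on this read-out higher numbers stand for weaker inhibition and lower numbers for stronger inhibition), compound 1 gives 7860 nM
compound 2 `O=C(Nc1ccc(Cl)cc1)Nc1nc(Sc2c[nH]c3ccccc23)cc(N2CCCC2)n1`, in this assay compound 2 gives 5850 nM

Compound 2 has the lowest of the two numbers in this assay, though its gap to compound 1 lies within the scatter, so neither can be called the stronger. Compound 3 `O=C(Nc1ccccc1)Nc1nc(Sc2c[nH]c3ccccc23)cc(N2CCCC2)n1` differs from compound 2 in one place: hydrogen in place of chloro on an aromatic carbon. Going by the values given here, no measured pair shows this change, so only a modest step is expected for compound 3, if any beyond the scatter, and it is estimated as a 1.2-fold higher number from compound 2 to compound 3 (0.08 log units; within the scatter). Compound 3 is therefore expected to give 7000 nM in this assay, within 3000 nM to 16000 nM.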

Compound 3, half-maximal inhibitory concentration: 7890 nM
Estimate against measurement, compound 3: 1.1-fold (0.05 log units) below; low and high end bracket the measured number.
By their numbers in this assay, from the lowest: compounds 2, 1 and 3 (each within the scatter of the next).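

In this assay, hydrogen in place of chloro on the aromatic carbon gives a 1.3-fold higher number from compound 2 to compound 3 (0.13 log units; within the scatter), so the chloro of the 4-chlorophenyl group makes no readable difference among these compounds. Pyrrolidin-1-yl in place of cyclopropylamino gives a 1.0-fold higher number from compound 1 to compound 3 (0.00 log units; within the scatter), so that position likewise shows no readable difference. Nothing measured here bears on these results.

Going by these compounds, whether a methoxy or a nitrile on that aromatic carbon would move the number beyond the scatter remains open. The same holds for a morpholin-4-yl group in place of pyrrolidin-1-yl.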